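Aryl replacement on the shared core: outlook for compound 4

The source may report more compounds than this note shows. Statements on the series, on what has been measured and on what is new or still open speak of the compounds shown alone.

Measured compounds:
- compound 1, `COc1ccc2c(OCc3nnc4sc(-c5ccc[nH]5)nn34)ccnc2c1` — in a functional assay on EBC-1 cells (Homo sapiens) for antiproliferative activity, with a stated time of 72 h (a lower number here means a stronger inhibitor, a higher number a weaker inhibitor), compound 1 gives 313 nM
- compound 2, `COc1ccc2c(OCc3nnc4sc(-c5cccn5C)nn34)ccnc2c1` — in this assay compound 2 gives "not determined" (no result reported)
- compound 3, `COc1ccc2[nH]c(-c3nn4c(COc5ccnc6cc(OC)ccc56)nnc4s3)cc2c1` — in this assay compound 3 gives 85.6 nM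

Among the measured compounds shown here, compound 3 holds the lowest of the two numbers available, the only comparison being compound 1, which lies beyond the scatter above it: a 3.7-fold lower number from compound 1 to compound 3 (0.56 log units; beyond the scatter). Compound 2 contributes no number.

Compound 4, `COc1ccc2c(OCc3nnc4sc(-c5cc(F)c(F)c(F)c5)nn34)ccnc2c1`, is not yet measured. It differs from compound 3 as follows: 3,4,5-trifluorophenyl in place of 5-methoxy-1H-indol-2-yl on an aromatic carbon. For the measured compounds named here, the change is at the same carbon of the shared core that was varied between compound 1 and compound 3, so a 3.7-fold lower number from compound 1 to compound 3 (0.56 log units; beyond the scatter) is the only measured step that bears on it, and it does so only loosely: it shows that this position tolerates a change of aryl with a modest shift in the readout, but neither measured group resembles the 3,4,5-trifluorophenyl that enters. Going by the values given here, no measured pair covers the loss of a hydrogen-bond donor and acceptor at this carbon. A larger uncertainty is therefore attached to the expectation.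

Estimate: compound 4 is expected to fall at 350 nM, within 80 nM to 1500 nM, the step from compound 3 being estimated as a 4.1-fold higher number from compound 3 to compound 4 (0.61 log units; beyond the scatter).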

Compound 4, half-maximal inhibitory concentration: 403 nM
Beside the measured number, compound 4's estimate is 1.2-fold (0.06 log units) below it, and the stated range covers the measured number.
By their numbers in this assay, from the lowest: compound 3; then compounds 1 and 4 (each within the scatter of the next).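

Replacing 5-methoxy-1H-indol-2-yl, with 1 hydrogen-bond donor and 1 hydrogen-bond acceptor, by 3,4,5-trifluorophenyl, with 0 of each, gives a 4.7-fold higher number from compound 3 to compound 4 (0.67 log units; beyond the scatter) in this assay and shows that this carbon also accepts a single six-membered aromatic ring of carbon only without loss of a measurable number. Against the smaller 1H-pyrrol-2-yl the same group gives a 1.3-fold higher number from compound 1 to compound 4 (0.11 log units; within the scatter) and so cannot be told apart from it in this assay, which leaves 5-methoxy-1H-indol-2-yl as the only group among the three whose steps to both others lie beyond the scatter. The lower number therefore does not simply follow the presence of a hydrogen on a ring nitrogen, since compound 1 also has one and goes against such a pattern.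

Nothing available gives a reason for these steps. Open, as far as these compounds go, is whether the lower number of compound 3 belongs to the fused ring or to its methoxy group, a question that an unsubstituted 1H-indol-2-yl would address, along with whether a phenyl bearing a methoxy group, an amine or a carboxylic acid behaves like the 3,4,5-trifluorophenyl at this carbon.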